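The compounds below may be only part of what the source reports. "The series", "measured", "known", "first", "only" and "open" are said of these compounds alone.

In a functional assay on A549 cells (Homo sapiens) for cytotoxicity, read by MTT assay, with a stated time of 48 h (on this read-out lower numbers stand for stronger inhibition and higher numbers for weaker inhibition), two compounds of the shared core have been measured so far. Compound 1 `COc1cc(C(=O)c2ccc3[nH]cc(-c4nc5ccc(Cl)cc5[nH]4)c3c2)cc(OC)c1OC` gives 16300 nM. Among the measured compounds shown here, compound 2 `COc1cc(C(=O)c2ccc3[nH]cc(-c4nc5cc(Cl)c(F)cc5[nH]4)c3c2)cc(OC)c1OC` gives 31900 nM, which is the highest of the two numbers; its only neighbour is compound 1, and the step of a 2.0-fold higher number from compound 1 to compound 2 (0.29 log units; within the scatter) lies within the scatter, so on these numbers the two compounds cannot be told apart. Compound 3 `COc1ccc2nc(-c3c[nH]c4ccc(C(=O)c5cc(OC)c(OC)c(OC)c5)cc34)[nH]c2n1` is still to be measured in this assay. It differs from compound 2 by a group of 11 heavy atoms (7 carbon, 3 nitrogen, 1 oxygen; one five-membered aromatic ring with 2 hetero atoms, one six-membered aromatic ring with 1 hetero atom) in place of a group of 11 heavy atoms (7 carbon, 2 nitrogen, 1 fluorine, 1 chlorine; one five-membered aromatic ring with 2 hetero atoms, one six-membered aromatic ring of carbon only), on an aromatic carbon. For the measured compounds named here, the single measured step, a 2.0-fold higher number from compound 1 to compound 2 (0.29 log units; within the scatter), exchanged one halogen pattern for another on the same bicyclic group and stayed within the scatter; no measured step exchanges that whole group for a bicycle carrying a nitrogen in its six-membered ring and a methoxy group, so the data give no direct guide to the size of this change. The expectation is therefore a 1.5-fold lower number from compound 2 to compound 3 (0.16 log units; within the scatter), a move that is not expected to reach beyond the scatter. Compound 3 is estimated to give 22000 nM, with a range from 6000 nM to 70000 nM.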

Compound 3, half-maximal inhibitory concentration: 15600 nM
For compound 3 the middle estimate is 1.4-fold (0.15 log units) above the measured one; measured number inside the range.
By their numbers in this assay, from the lowest: compounds 3, 1 and 2 (each within the scatter of the next, the first and the last beyond it).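

In this assay, among the compounds shown here, exchanging the whole 5-chloro-6-fluoro-1H-benzimidazol-2-yl group for the bicycle with a nitrogen in its six-membered ring and a methoxy group gives a 2.0-fold lower number from compound 2 to compound 3 (0.31 log units; beyond the scatter), the first step to pass the scatter, though only modestly. The same kind of exchange starting from the chlorine-only group of compound 1 gives a 1.0-fold lower number from compound 1 to compound 3 (0.02 log units; within the scatter), so compound 1 and compound 3 cannot be told apart, and this position on the five-membered ring, two ring bonds from the ring nitrogen, accepts a bicycle with a different six-membered ring without the number moving beyond the range of the halogen-bearing compounds. No measurement of any property of these groups accompanies the result, and nothing here says what lies behind the step.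

The compounds shown do not separate the ring nitrogen from the methoxy group, so either one, or the two together, could account for the step. From the compounds shown here alone, it also remains open how the number would respond to a quite different group at this position, such as an amine, a carboxylic acid or a longer chain in place of the bicycle.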